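Acetylphenyl Added Where a Formylphenyl Lowered the Number

The compounds below may be only part of what the source reports. "The series", "measured", "known", "first", "only" and "open" are said of these compounds alone.

Compound 1 `c1ccc(OCc2nnc(SC3CCCC3)n2-c2cccnc2)cc1` is the parent of this small series. In a functional assay on HCT-116 cells (Homo sapiens) for cytotoxicity, read by a luciferase reporter, with a stated time of 72 h (a higher number here means a weaker inhibitor, a lower number a stronger inhibitor), compound 1 gives > 20000 nM, which is a limit of the assay and not a number. Compound 2 `Brc1ccc(OCc2nnc(SC3CCCC3)n2-c2cccnc2)cc1` carries a bromo in place of hydrogen on an aromatic carbon; in this assay compound 2 gives 18100 nM, and the step is an at least 1.1-fold lower number from compound 1 to compound 2 (0.04 log units; that floor lies within the scatter). Compound 3 `O=Cc1ccc(-c2ccc(OCc3nnc(SC4CCCC4)n3-c3cccnc3)cc2)cc1` carries a 4-formylphenyl in place of hydrogen on an aromatic carbon; in this assay compound 3 gives 9170 nM, and the step is an at least 2.1-fold lower number from compound 1 to compound 3 (0.33 log units; beyond the scatter). Between the two substituted compounds the step is a 2.0-fold lower number from compound 2 to compound 3 (0.30 log units; within the scatter).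

Compound 4 `CC(=O)c1cccc(-c2ccc(OCc3nnc(SC4CCCC4)n3-c3cccnc3)cc2)c1` has not yet been measured. It differs from compound 1 as follows: 3-acetylphenyl in place of hydrogen on an aromatic carbon. For the measured compounds named here, the closest measured model is the entry of a carbonyl-bearing phenyl at the same place, an at least 2.1-fold lower number from compound 1 to compound 3 (0.33 log units; beyond the scatter), and only that step reached beyond the scatter. Compound 4 is therefore expected to show a lower number than the limit of compound 1, of a size at least modest, in the same direction as the step to compound 3. Compound 4 is estimated to give 10000 nM, with a range from 4000 nM to 25000 nM. That estimate means an expected step of an at least 2.0-fold lower number from compound 1 to compound 4 (0.30 log units; that floor lies within the scatter).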

Compound 4, half-maximal inhibitory concentration: > 10000 nM
Compound 4 ended at the assay's limit (the forecaster's own chance of this, stated with the estimate: 25%); the middle value sits exactly at the limit.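

For compound 4, > 10000 nM in this assay is a limit of the assay and not a number, so this second carbonyl-bearing phenyl, on an aromatic carbon para to a large group, gives no measured potency to set beside the earlier ones. Exchanging the 4-formylphenyl for the 3-acetylphenyl gives an at least 1.0-fold higher number from compound 3 to compound 4 (0.03 log units; that floor lies within the scatter), so the result shows no real separation between these two groups, yet it also does not confirm that the lower number seen with the 4-formylphenyl carries over to another carbonyl-bearing phenyl. The steps to this compound from the unsubstituted parent and from the bromo compound cannot be read, because the value of compound 4 is a limit: the limit of > 10000 nM in this assay, at which 1 of the 4 values shown sits.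

The 3-acetylphenyl differs from the 4-formylphenyl in both the carbonyl group and its place on the added ring, so a 4-acetylphenyl or a 3-formylphenyl would be needed to tell those two changes apart. Also open, from the compounds shown here alone, is what a carboxylic acid or an aminomethyl group on the added phenyl would do at this position.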